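The compounds below may be only part of what the source reports. "The series", "measured", "known", "first", "only" and "open" are said of these compounds alone.

Measured so far in an assay on isolated protein for inhibition of G protein-coupled receptor kinase 6 (Homo sapiens), read by scintillation counting, radiometric assay and 33P incorporation, with a stated time of 80 min, in the presence of a further agent that is not named here; on this read-out higher numbers stand for weaker inhibition and lower numbers for stronger inhibition: compound 1 `CCc1cc(Nc2nc(N[C@@H](C)c3ccc(F)cc3)nc3ccccc23)n[nH]1` gives 120 nM; compound 2 `CCc1cc(Nc2nc(N[C@@H](C)c3ccc(Cl)cn3)nc3cccc(OC)c23)n[nH]1` gives 3.5 nM; compound 3 `CCc1cc(Nc2nc(NCc3ccc(Cl)cc3)nc3cccc(OC)c23)n[nH]1` gives 16 nM.

Compound 3 stands second highest of the three numbers, its nearest neighbour being compound 2 and its furthest compound 1. Among the measured compounds shown here, the one step on record, a 4.6-fold higher number from compound 2 to compound 3 (0.66 log units; beyond the scatter), concerns the group on the ring nitrogen, not the fused ring that is changed now. Compound 4 `CCc1cc(Nc2nc(NCc3ccc(Cl)cc3)nc3cccc(C)c23)n[nH]1` differs from compound 3 by methyl in place of methoxy on an aromatic carbon. For the measured compounds named here, no measured step bears on this change; compound 1, which carries no group at that place but also a different side group, gives a higher number than compound 3, and nothing more can be read from that pair. Compound 4 is therefore expected to show a small step, a 1.9-fold higher number from compound 3 to compound 4 (0.27 log units; within the scatter), estimated at 30 nM in this assay, between 10 nM and 100 nM.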

Compound 4, half-maximal inhibitory concentration: 27 nM
The estimate for compound 4 lay 1.1-fold (0.05 log units) above the measured number, and the stated range covers the measured number.
By their numbers in this assay, from the lowest: compound 2; then compounds 3 and 4 (each within the scatter of the next); then compound 1.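

In this assay, among the compounds shown here, methyl in place of methoxy on this aromatic carbon gives a 1.7-fold higher number from compound 3 to compound 4 (0.23 log units; within the scatter), the first direct reading at this place. With this side group, then, losing the oxygen and the hydrogen-bond acceptor of methoxy moves the number by no more than the scatter. Nothing measured here offers an explanation for this result. The compounds shown leave open whether an ethoxy group, an amine or a chlorine at this place would behave alike. They also leave open whether the same exchange holds with the side group of compound 2.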